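Cyano for hydroxy on the shared core

The compounds below may be only part of what the source reports. "The series", "measured", "known", "first", "only" and "open" are said of these compounds alone.

Going by the values given here, compound 2 `O=c1[nH]c2ccc(O)cc2oc1=O` gives 170000 nM in a functional assay with Rattus norvegicus as the target (on this read-out lower numbers stand for stronger inhibition and higher numbers for weaker inhibition), and stands highest of the three numbers measured so far. Compound 1 `O=C(O)c1ccc2[nH]c(=O)c(=O)oc2c1` gives 16000 nM and compound 3 `CCOC(=O)c1ccc2oc(=O)c(=O)[nH]c2c1` gives 10000 nM; both sit well under compound 2, the step from compound 1 to compound 2 being an 11-fold higher number from compound 1 to compound 2 (1.03 log units; beyond the scatter) and the gap to compound 3 larger still.

Compound 4 `N#Cc1ccc2[nH]c(=O)c(=O)oc2c1` differs from compound 2 in one place: cyano in place of hydroxy on an aromatic carbon.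

Among the compounds with values here, the only measured step that touches this position is an 11-fold higher number from compound 1 to compound 2 (1.03 log units; beyond the scatter), where hydroxy replaced carboxy and the number rose strongly. Within the data shown here, no cyano analogue is available, so the size of the present step cannot be read directly. What the numbers do show is that hydroxy is the outlier here: both other substituents at this place, carboxy in compound 1 and the ethyl ester in compound 3, return numbers in a tight band far below compound 2. A change away from hydroxy toward another group without a donor is therefore expected to move the number down, toward that band, though with wide uncertainty.

Compound 4 is thus expected to reach about 30000 nM, in the range 8000 nM to 120000 nM, corresponding to an estimated step of a 5.7-fold lower number from compound 2 to compound 4 (0.75 log units; beyond the scatter).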

Compound 4, half-maximal inhibitory concentration: 15000 nM
Compound 4: the middle estimate sits 2.0-fold (0.30 log units) above what was measured; low and high end bracket the measured number.
By their numbers in this assay, from the lowest: compounds 3, 4 and 1 (each within the scatter of the next); then compound 2.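

In this assay, cyano in place of hydroxy on this aromatic carbon gives an 11-fold lower number from compound 2 to compound 4 (1.05 log units; beyond the scatter), a direct reading of this change that is close in size to the earlier 11-fold higher number from compound 1 to compound 2 (1.03 log units; beyond the scatter). Cyano and carboxy cannot be told apart at this place, with a 1.1-fold lower number from compound 1 to compound 4 (0.03 log units; within the scatter), so among compound 1, compound 2 and compound 4 hydroxy alone stands apart, and none of the three goes against this. No measurement is at hand that ties the large step to any property of hydroxy or cyano.

Going by these compounds, three groups at one position give only a narrow view, so it remains open whether an amine or a methoxy group here would stay with hydroxy at the high end or join cyano and carboxy. On these data alone, it also remains open whether a halogen such as fluorine or chlorine, or a longer chain such as propyl, would keep the number in the range shared by compound 1 and compound 4 or move it outside that range.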